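A few compounds are considered here, and "the series" means these few. Any claim that something is new, unique, unknown or untested is made for them only; others in the source may bear on it.

Compounds measured so far:
compound 1 `Cc1ccc(S(=O)(=O)c2cnc3c(F)cccc3c2N2CCC(C)CC2)cc1`: 93%
compound 2 `CC1CCN(c2c(S(=O)(=O)c3ccccc3)cnc3ccc(Cl)cc23)CC1`: 59%

In an assay on isolated protein for displacement of a labelled ligand from metabotropic glutamate receptor 5 (Homo sapiens), with a stated time of 60 min, tested at 1 uM (on this read-out higher numbers stand for more inhibition at the one concentration tested (going by the name of the read-out) and lower numbers for less inhibition), compound 1 gives 93%, the higher of the two numbers. Compound 2 gives 59% in this assay, a gap beyond the usual scatter. Compound 3 `COc1ccc(S(=O)(=O)c2cnc3c(F)cccc3c2N2CCC(C)CC2)cc1` is not yet measured; it differs from compound 1 by methoxy in place of methyl on an aromatic carbon. Going by the values given here, no measured pair shows this exact change, so there is no direct precedent. Since compound 1 already sits near the top of the scale, the expected step is small, either none beyond the scatter or a slight drop. Compound 3 is expected to give about 85%, with a likely range from 65% to 98%. This estimate means an expected step of a number 8 percentage points lower from compound 1 to compound 3 (within the scatter).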

Compound 3, a percentage reported as inhibition, at one concentration (the size of the read-out at that concentration, not a potency): 67%
For compound 3 the middle estimate is 18 percentage points above the measured one, within the range that was stated.
By their numbers in this assay, from the lowest: compounds 2 and 3 (each within the scatter of the next); then compound 1.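

In this assay the change from 4-methylphenyl to 4-methoxyphenyl gives a number 26 percentage points lower from compound 1 to compound 3 (beyond the scatter) and so provides the first step read at a single place. It shows that this position on the aromatic ring responds to a small exchange, which compound 1 and compound 2 could not show, as they differ in more than one place. Nothing measured here accounts for the step. The compounds shown leave open how a chlorine, an ethyl group or a dimethylamino group would read at this position.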